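The source may hold more compounds than are shown below. What is called first, only, known or untested is meant among the compounds shown, and "the series" means these compounds.

Compound 3 `S=c1oc(-c2ccc3c(c2)OCCO3)nn1CNc1ccccc1Cl` gives 7230 nM in a functional assay, with a stated time of 6 min (a higher number here means a weaker inhibitor, a lower number a stronger inhibitor), the second highest of three numbers; compound 2 `FC(F)(F)c1cccc(NCn2nc(-c3ccc4c(c3)OCCO4)oc2=S)c1` at 7620 nM lies nearest and compound 1 `S=c1oc(-c2ccc3c(c2)OCCO3)nn1CNc1ccccc1` at 5140 nM furthest, both within the scatter. Compound 4 `O=[N+]([O-])c1ccccc1NCn1nc(-c2ccc3c(c2)OCCO3)oc1=S` differs from compound 3 by nitro in place of chloro on an aromatic carbon. For the measured compounds named here, no measured step swaps one substituent for another on that ring; the two steps that bear on it each introduce a single substituent rather than exchanging one, a 1.5-fold higher number from compound 1 to compound 2 (0.17 log units; within the scatter) and a 1.4-fold higher number from compound 1 to compound 3 (0.15 log units; within the scatter), and both stay within the scatter. Compound 4 is therefore expected to show a step of a 1.0-fold lower number from compound 3 to compound 4 (0.01 log units; within the scatter), nothing beyond the scatter. Compound 4 is estimated at 7000 nM, between 3500 nM and 14000 nM.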

Compound 4, half-maximal inhibitory concentration: 10900 nM
For compound 4 the middle estimate is 1.6-fold (0.19 log units) below the measured one; measured number inside the range.
By their numbers in this assay, from the lowest: compounds 1, 3, 2 and 4 (each within the scatter of the next, the first and the last beyond it).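

In this assay, nitro in place of chloro on the aromatic carbon ortho to a large group gives a 1.5-fold higher number from compound 3 to compound 4 (0.18 log units; within the scatter) and so stays within the scatter, which means this exchange does not separate the two groups. For the compounds shown here, measured against the unsubstituted ring, however, nitro gives a 2.1-fold higher number from compound 1 to compound 4 (0.33 log units; beyond the scatter) and is the first substituent on this ring to pass beyond the scatter, though only modestly. Nothing available explains this step. As far as these compounds go, whether an amine or a carboxylic acid at this position would give a lower or higher number remains open. So does the effect of nitro elsewhere on the ring.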